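The source may report more compounds than this note shows. Statements on the series, on what has been measured and on what is new or still open speak of the compounds shown alone.

Compound 1 `O=C(Nc1ccc(Oc2ccnc3[nH]ccc23)cc1)c1nn(-c2ccc(Br)cc2F)ccc1=O` gives 26100 nM in a functional assay on A549 cells (Homo sapiens) for cytotoxicity, read by MTT assay, with a stated time of 72 h; on this read-out higher numbers stand for weaker inhibition and lower numbers for stronger inhibition. Compound 2 `O=C(Nc1ccc(Oc2ccnc3[nH]ccc23)cc1)c1nn(-c2ccc(Cl)c(F)c2)ccc1=O`, which carries 4-chloro-3-fluorophenyl in place of 4-bromo-2-fluorophenyl on an aromatic nitrogen, gives 2580 nM in this assay, a step of a 10-fold lower number from compound 1 to compound 2 (1.01 log units; beyond the scatter). Compound 3 `Cn1ccc2c(Oc3ccc(NC(=O)c4nn(-c5ccc(Br)cc5F)ccc4=O)cc3)ccnc21` differs from compound 1 in its core by methyl in place of hydrogen on an aromatic nitrogen, and in this assay compound 3 gives 35700 nM, a step of a 1.4-fold higher number from compound 1 to compound 3 (0.14 log units; within the scatter). Compound 4 `Cn1ccc2c(Oc3ccc(NC(=O)c4nn(-c5ccc(Cl)c(F)c5)ccc4=O)cc3)ccnc21` has not been measured in this assay; it carries 4-chloro-3-fluorophenyl in place of 4-bromo-2-fluorophenyl on an aromatic nitrogen, the same change that takes compound 1 to compound 2, at the same place. From compound 3 to compound 4 a step of a 10-fold lower number from compound 3 to compound 4 (1.01 log units; beyond the scatter) is expected, because the same change gave a 10-fold lower number from compound 1 to compound 2 (1.01 log units; beyond the scatter) on the other core. On that basis compound 4 is estimated at 3500 nM, between 1200 nM and 10000 nM, in this assay.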

Compound 4, half-maximal inhibitory concentration: > 60000 nM
Compound 4 ended at the assay's limit; the forecaster's own chance of this, stated with the estimate: 3%; at least 17-fold (1.23 log units) between middle value and limit.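

Compound 4 gives > 60000 nM in this assay, and this is a limit of the assay, not a number. The swap to 4-chloro-3-fluorophenyl gives an at least 1.6-fold higher number from compound 3 to compound 4 (0.22 log units; that floor lies within the scatter), so on this pair of cores the earlier drop does not carry over: the same change on two cores in this assay, a 10-fold lower number (1.01 log units; beyond the scatter) from compound 1 to compound 2 and an at least 1.6-fold higher number (0.22 log units; that floor lies within the scatter) from compound 3 to compound 4, at least 17-fold (1.23 log units) apart, beyond the scatter of two such steps Likewise, methyl on the aromatic nitrogen gives an at least 23-fold higher number from compound 2 to compound 4 (1.36 log units; beyond the scatter), so its effect depends on the group on the other ring, although a single pair of cores with a limit on one corner shows neither the full size of this gap nor why it arises: the same change on two cores in this assay, a 1.4-fold higher number (0.14 log units; within the scatter) from compound 1 to compound 3 and an at least 23-fold higher number (1.36 log units; beyond the scatter) from compound 2 to compound 4, at least 17-fold (1.23 log units) apart, beyond the scatter of two such steps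

The compounds shown leave open whether the mismatch persists with other groups on the aromatic nitrogen, such as unsubstituted phenyl. They also leave open what ethyl in place of methyl on the core would do.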